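Aryl ether for imidazolyl: expectation for compound 4

The source may hold more compounds than are shown below. What is called first, only, known or untested is meant among the compounds shown, and "the series" means these compounds.

Values in an ADME assay on MCF7 cells (Homo sapiens) for inhibition (on this read-out higher numbers stand for weaker inhibition and lower numbers for stronger inhibition), each of them a limit:
- compound 1 `COC(=O)c1cc2c(F)c(F)c(-n3ccnc3)c(F)c2s1`: > 100000 nM
- compound 2 `COC(=O)c1cc2c(F)c(F)c(Sc3ccc(C(C)(C)C)cc3)c(F)c2s1`: > 50000 nM
- compound 3 `O=C(c1ccccc1)c1cc2c(F)c(F)c(-n3ccnc3)c(F)c2s1`: > 60000 nM

Compound 3 stands at the limit of > 60000 nM in this assay, at which 1 of the 3 values shown sits, and offers no number to measure from. Compound 4 `O=C(c1ccccc1)c1cc2c(F)c(F)c(Oc3ccccc3Br)c(F)c2s1` carries 2-bromophenoxy in place of 1H-imidazol-1-yl on an aromatic carbon, counted as 2-bromophenoxy in place of 1H-imidazol-1-yl on an aromatic carbon with the rest unchanged. Among the measured compounds shown here, the one measured step that the two limits leave unreadable from compound 1 to compound 3 gives no size to carry over. Compound 2, also without 1H-imidazol-1-yl, gives the limit > 50000 nM in this assay as well. The expected step is an at least 1.2-fold lower number from compound 3 to compound 4 (0.07 log units; that floor lies within the scatter) and no direction beyond the scatter can be argued. Compound 4 is estimated at 50000 nM with a range from 15000 nM to 150000 nM, and a limit rather than a number may well be expected for it.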

Compound 4, half-maximal inhibitory concentration: > 25000 nM
Compound 4: no number, only a limit; the forecaster's own chance of this, stated with the estimate: 65%; the middle value lies beyond the limit too.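

Compound 3 gives only a limit in this assay, > 60000 nM. Compound 4 is also a limit, > 25000 nM, so no step can be read between compound 3 and compound 4. Going by these compounds, the size and direction of any change with 2-bromophenoxy in place of 1H-imidazol-1-yl remain open.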